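Swapping phenoxy for chloro on a shared arylidene oxindole core

This account rests on a few compounds, and the source may have more. Where it says the series, first, only, none or still open, it means among the compounds named here.

Measured compounds:
- compound 1 `O=C1/C(=C\c2cc3ccccc3nc2Cl)c2ccccc2N1c1c(Cl)cccc1Cl`: "not determined" (no result reported)
- compound 2 `Cc1ccc2nc(Cl)c(/C=C3\C(=O)N(c4c(Cl)cccc4Cl)c4ccccc43)cc2c1`: "not determined" (no result reported)
- compound 3 `O=C1/C(=C\c2cccc(Oc3ccccc3)c2)c2ccccc2N1c1c(Cl)cccc1Cl`: 6 ug/mL

For the measured compounds named here, compound 3 is the only compound of the three with a number in a functional assay on MOLT-4 cells (Homo sapiens) for cytotoxicity, read by MTT assay, with a stated time of 72 h; a lower number here means that less compound is needed, a higher number that more compound is needed for the effect; for compound 1 and compound 2 this assay gave no result, so compound 3 stands alone and no ordering can be drawn. Compound 4 `O=C1/C(=C\c2cccc(Cl)c2)c2ccccc2N1c1c(Cl)cccc1Cl` differs from compound 3 in one place: chloro in place of phenoxy on an aromatic carbon, meta to a large group. Going by the values given here, no step between measured compounds is known here, so the size of this change is uncertain. Compound 4 is expected to need somewhat more compound than compound 3, a step of a 1.5-fold higher number from compound 3 to compound 4 (0.18 log units; within the scatter) that may not exceed the scatter. Compound 4 is thus estimated at 9 ug/mL in this assay, within a range of 3 ug/mL to 30 ug/mL.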

Compound 4, concentration for half-maximal effect: 6 ug/mL
The estimate for compound 4 lay 1.5-fold (0.18 log units) above the measured number; the measured number falls inside the stated range.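

In this assay the swap of phenoxy for chloro gives no change at the digits printed from compound 3 to compound 4 (within the scatter), so this position, on an aromatic carbon and meta to a large group, holds either substituent with no visible difference in the number. Compound 1 and compound 2 offered no number, so this is the only readable step among these compounds. No measurement shown here accounts for this result. From the compounds shown here alone, whether an amine, a carboxylic acid or a longer alkoxy chain at this position would read alike stays open. So does whether the same swap would behave this way on another core.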